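A few compounds are considered here, and "the series" means these few. Any claim that something is new, unique, unknown or untested is made for them only; others in the source may bear on it.

Three compounds from this series have been measured in a functional assay on MDA-MB-231 cells (Homo sapiens) for antiproliferative activity, read by MTT assay, with a stated time of 24 h; on this read-out higher numbers stand for weaker inhibition and lower numbers for stronger inhibition:

Compound 1, `COc1ccc(-c2cc(/C=C/C(=O)c3ccc(C)cc3)nc3cc(-c4ccccc4)nn23)cc1OC`, gives 19800 nM.
Compound 2, `COc1ccc(-c2cc(/C=C/C(=O)c3ccc(C)c(C)c3)nc3cc(-c4ccccc4)nn23)cc1OC`, gives 11500 nM.
Compound 3, `COc1cc(-c2cc(/C=C/C(=O)c3ccc(C)cc3)nc3cc(-c4ccccc4)nn23)cc(OC)c1OC`, gives 23900 nM.

Compounds 2 and 1 differ by a single change, (hydrogen in place of methyl on an aromatic carbon), and this change produced a 1.7-fold higher number from compound 2 to compound 1 (0.24 log units; within the scatter). Compounds 1 and 3 also differ in one place, methoxy in place of hydrogen on an aromatic carbon, and that step gave a 1.2-fold higher number from compound 1 to compound 3 (0.08 log units; within the scatter). Compounds 2 and 3 differ in more than one place, so the difference between their two cores is not broken down here; what their two values show is that compound 3 gives the higher number of the two, with a gap beyond the usual scatter.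

Compound 4, `COc1cc(-c2cc(/C=C/C(=O)c3ccccc3)nc3cc(-c4ccccc4)nn23)cc(OC)c1OC`, is not yet measured. It is related to compound 3 by hydrogen in place of methyl on an aromatic carbon. Among the compounds with values here, this is the same kind of change as the one from compound 2 to compound 1, but not the same: in the earlier pair the carbon carrying the change was ortho to a methyl group and meta to a large group, whereas in compound 3 it is para to a large group.

Since the earlier removal of a methyl gave a 1.7-fold higher number from compound 2 to compound 1 (0.24 log units; within the scatter), the step from compound 3 to compound 4 is expected to be of similar size, a 1.4-fold higher number from compound 3 to compound 4 (0.15 log units; within the scatter). On that basis compound 4 is estimated at 34000 nM in this assay, most likely between 17000 nM and 68000 nM.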

Compound 4, half-maximal inhibitory concentration: 15800 nM
Compound 4: the middle estimate sits 2.2-fold (0.33 log units) above what was measured; the whole stated range lies above it.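

Replacing methyl with hydrogen in the change from 4-methylphenyl to phenyl produced a 1.5-fold lower number from compound 3 to compound 4 (0.18 log units; within the scatter) in this assay. Set beside the same replacement on the other core, this step cannot be told apart from the earlier one: the same change on two cores in this assay, a 1.7-fold higher number (0.24 log units; within the scatter) from compound 2 to compound 1 and a 1.5-fold lower number (0.18 log units; within the scatter) from compound 3 to compound 4, 2.6-fold (0.42 log units) apart, within the scatter of two such steps. This shows that, across these two pairs, the replacement produces no step beyond the scatter on either core, so there is no sign that the core alters its outcome; it does not show that the methyl has the same effect on both cores, or that it has any real effect at all, and two pairs set no rule for the whole series.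

The compounds shown offer only methyl or hydrogen at this place on the ring, with a second methyl in compound 2, so they leave open whether a group such as chloro, a carboxylic acid or an amine, or a longer chain such as propyl, would give a step that stands clear of the scatter. They also leave open whether any such step would carry between the core of compound 1 and the core of compound 3.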